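The source may report more compounds than this note shows. Statements on the series, on what has been measured and on what is new or still open speak of the compounds shown alone.

Measured in a functional assay on MCF7 cells (Homo sapiens) for antiproliferative activity, read by MTT assay, with a stated time of 72 h; on this read-out lower numbers stand for stronger inhibition and higher numbers for weaker inhibition:
- compound 1 `CC1=CC[C@H]2[C@H](CC[C@]2(C)O)C(C)(C)[C@@H]1CC[C@H]1[C@]2(C)CC[C@H](OC(=O)c3ccc(C)cc3)C(C)(C)O[C@H]2CC[C@@]1(C)O`: > 50000 nM
- compound 2 `CC1=CC[C@H]2[C@H](CC[C@]2(C)O)C(C)(C)[C@@H]1CC[C@H]1[C@]2(C)CC[C@H](OC(=O)c3ccc(F)cc3)C(C)(C)O[C@H]2CC[C@@]1(C)O`: 33500 nM

The result of compound 1 is the limit of > 50000 nM in this assay, at which 1 of the 2 values shown sits, which is a limit and not a number. Among the compounds with values here, compound 2 is the only compound with an actual number, 33500 nM.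

Next comes compound 3 `CC1=CC[C@H]2[C@H](CC[C@]2(C)O)C(C)(C)[C@@H]1CC[C@H]1[C@]2(C)CC[C@H](OC(=O)c3ccc([N+](=O)[O-])cc3)C(C)(C)O[C@H]2CC[C@@]1(C)O`, with nitro in place of fluoro on an aromatic carbon. This is nitro in place of fluoro on an aromatic carbon, para to a large group.

Within the data shown here, only one measured step bears on this change, also a replacement on an aromatic carbon: an at least 1.4-fold lower number from compound 1 to compound 2 (0.17 log units; that floor lies within the scatter). That step is open-ended and gives no firm size, so no change beyond the scatter is expected in this assay, in either direction. The expected 1.0-fold higher number from compound 2 to compound 3 (0.02 log units; within the scatter) is therefore small. For compound 3 the estimated value is 35000 nM, with an expected range from 15000 nM to 60000 nM.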

Compound 3, half-maximal inhibitory concentration: 21600 nM
The estimate for compound 3 lay 1.6-fold (0.21 log units) above the measured number; the range from low to high includes it.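

In this assay, exchanging fluoro for nitro on the aromatic carbon para to a large group gives a 1.6-fold lower number from compound 2 to compound 3 (0.19 log units; within the scatter), so these two groups cannot be separated at this position. Within the data shown here, exchanging methyl for nitro at the same place gives an at least 2.3-fold lower number from compound 1 to compound 3 (0.36 log units; beyond the scatter), the first step that clears the scatter and the first sign that this group can move the read-out at all. That step remains only a floor because compound 1 stands at a limit and not at a number: the limit of > 50000 nM in this assay, at which 1 of the 3 values shown sits.

Still open, going by these compounds, is whether an amine, a carboxylic acid or a methoxy group on the same aromatic carbon would separate from compound 2 by more than the scatter. The full size of the step from methyl and the role of the ester link, for instance against an amide, also remain unresolved.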